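Series notes: removing the arylidene imine to a free amine

The source may hold more compounds than are shown below. What is called first, only, known or untested is meant among the compounds shown, and "the series" means these compounds.

Of the compounds shown here, three of a shared core have been measured in a functional assay on the whole organism (strain albino) for inhibition, with Rattus norvegicus as the target, read by paw edema, with stated times of 1 h and 3 h, at a dose of 20 mmol/kg by the intraperitoneal route; a lower number here means a weaker effect, a higher number a stronger effect of the compound at the dose given. Compound 1 `N#CC1=C(/N=C/c2ccccc2)N(c2ccccc2)C(=O)N2CCCCC(N3CCCC3)C12` gives 84%. Compound 2 `COc1ccc(/C=N/C2=C(C#N)C3C(N4CCCC4)CCCCN3C(=O)N2c2ccccc2)cc1` gives 75.3%. Compound 3 `N#CC1=C(/N=C/c2ccc([N+](=O)[O-])cc2)N(c2ccccc2)C(=O)N2CCCCC(N3CCCC3)C12` gives 91.7%, the top number of the three, though only one of its two margins is clear: a number 7.7 percentage points higher from compound 1 to compound 3 (within the scatter), while a number 16.4 percentage points higher from compound 2 to compound 3 (beyond the scatter); between the other two, a number 8.7 percentage points lower from compound 1 to compound 2 (within the scatter).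

Compound 4 `N#CC1=C(N)N(c2ccccc2)C(=O)N2CCCCC(N3CCCC3)C12` differs from compound 3 by one nitrogen atom in place of a group of 11 heavy atoms (7 carbon, 2 nitrogen, 2 oxygen; one six-membered aromatic ring of carbon only), on a double-bonded ring carbon. Among the compounds with values here, none of the measured steps bears on this change directly: all three concern a methoxy or nitro in place of hydrogen on an aromatic carbon of the very group that leaves, and they span only a modest range. What the free amino does in this assay is not shown by any measured pair, so the expectation rests on the bare range of the series. Compound 4 is expected to give 75%, within 55% to 92%, which as a step means a number 16.7 percentage points lower from compound 3 to compound 4 (beyond the scatter), an expected weakening of uncertain size that may well not exceed the scatter.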

Compound 4, a percentage reported as inhibition, in the whole organism at one dose (the size of the read-out at that dose, not a potency): 90.1%
Estimate against measurement, compound 4: 15.1 percentage points below; measured number inside the range.
By their numbers in this assay, from the lowest: compounds 2, 1, 4 and 3 (each within the scatter of the next, the first and the last beyond it).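

In this assay, the arylidene imine on the double-bonded ring carbon proves dispensable for the size of the read-out at the dose given: with amino in its place, there is a number 1.6 percentage points lower from compound 3 to compound 4 (within the scatter), and there is a number 6.1 percentage points higher from compound 1 to compound 4 (within the scatter), so neither step separates the free amino from those two imines. Against the methoxy-bearing imine the exchange gives a number 14.8 percentage points higher from compound 2 to compound 4 (beyond the scatter), the only one of the three new steps beyond the scatter, so the free amino matches the unsubstituted and nitro imines but not this one. No supporting evidence bears on why these numbers fall as they do.

On these data alone, whether the nitrogen at this position must stay unsubstituted remains open; a methylamino or an acetamido group there would test it. The single-dose read-out also leaves open whether the compounds with close numbers differ in potency.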